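Amino to Phenyl on the Sulfonyl Ring: Cytotoxicity Outlook

This account rests on a few compounds, and the source may have more. Where it says the series, first, only, none or still open, it means among the compounds named here.

Measured so far:
- Compound 1, `CC1CCN(C2CCN(S(=O)(=O)c3cccc(N)c3)CC2)CC1`: > 5000 nM
- Compound 2, `CC1CCN(C2CCN(S(=O)(=O)c3ccc(Cl)nc3)CC2)CC1`: > 10000 nM

Both measured compounds share one core and differ only in the ring on the sulfonyl sulfur. In an ADME assay on HCT-116 cells (Homo sapiens) for cytotoxicity, read by CellTiter-Glo, with a stated time of 72 h (a lower number here means a stronger inhibitor, a higher number a weaker inhibitor), compound 1 gives > 5000 nM, which is a limit of the assay rather than a number. Compound 2 in this assay also reaches only a limit, > 10000 nM. The change between them, 6-chloropyridin-3-yl in place of 3-aminophenyl on a sulfonyl sulfur, is therefore a step that the two limits leave unreadable from compound 1 to compound 2; with one value sitting at the limit of > 10000 nM in this assay, at which 1 of the 2 values shown sits, and the other at the limit of > 5000 nM in this assay, at which 1 of the 2 values shown sits, its size cannot be read. So compound 1 stands at a limit, and the one further value shown is a limit too.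

Compound 3, `CC1CCN(C2CCN(S(=O)(=O)c3cccc(-c4ccccc4)c3)CC2)CC1`, is not yet measured. It differs from compound 1 by phenyl in place of amino on an aromatic carbon. For the measured compounds named here, no measured step bears on this change, and neither limit can be turned into a direction. Compound 3 is therefore expected to give 8000 nM, within 3000 nM to 30000 nM. That estimate means a step that the limit leaves unreadable from compound 1 to compound 3, none beyond the scatter.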

Compound 3, half-maximal inhibitory concentration: > 5000 nM
Compound 3 gave a limit, no number; the forecaster's own chance of this, stated with the estimate: 70%; the middle value does not contradict the limit.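

In this assay compound 3 gives > 5000 nM, which is a limit and not a number. No step from compound 1 to compound 3 can be read, because both compounds stop at a limit: the limit of > 5000 nM in this assay, at which 2 of the 3 values shown sit.

The compounds shown leave open whether phenyl in place of amino changes cytotoxicity at all, and how large any such change would be.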